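Adding a bromothiophene to compound 1: cytotoxicity outlook

The source may report more compounds than this note shows. Statements on the series, on what has been measured and on what is new or still open speak of the compounds shown alone.

Among the compounds with values here, compound 1 `Cc1ccc(CN[C@@H]2C[C@H]3C[C@@H]([C@H]2C)C3(C)C)s1` is the only compound here with a measured number in an ADME assay on MDCK cells (Canis lupus familiaris) for cytotoxicity, read by microscopy, with a stated time of 48 h; on this read-out lower numbers stand for higher toxicity in this test and higher numbers for lower toxicity in this test: compound 1 gives 780 nM. Compound 2 `C[C@H]1[C@H](NCc2ccoc2)C[C@H]2C[C@@H]1C2(C)C` reaches only the limit of the test, > 100000 nM. Compound 3 `Cc1n[nH]cc1CN[C@@H]1C[C@H]2C[C@@H]([C@H]1C)C2(C)C` likewise reaches only the limit, > 100000 nM. These limits give an at least 120-fold higher number from compound 1 to compound 2 (2.10 log units; beyond the scatter) and an at least 120-fold higher number from compound 1 to compound 3 (2.10 log units; beyond the scatter), each swapping the whole ring of compound 1 for a different one; the limit of > 100000 nM in this assay, at which 2 of the 3 values shown sit, marks where both sit. Compound 4 `C[C@H]1[C@H](NCc2ccc(-c3ccc(Br)s3)s2)C[C@H]2C[C@@H]1C2(C)C` instead keeps the ring of compound 1 and changes (5-bromothiophen-2-yl in place of methyl on an aromatic carbon). Within the data shown here, no measured step touches this place, so the expectation rests on compound 1 alone and carries a wide range. Compound 4 is expected to give 500 nM, between 100 nM and 5000 nM. That amounts to an expected 1.6-fold lower number from compound 1 to compound 4 (0.19 log units; within the scatter).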

Compound 4, minimum cytotoxic concentration: 780 nM
Beside the measured number, compound 4's estimate is 1.6-fold (0.19 log units) below it, within the range that was stated.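

With no change at the digits printed from compound 1 to compound 4 (within the scatter) in this assay, the step shows that the methyl on the aromatic carbon next to the ring sulfur can give way to a much larger 5-bromothiophen-2-yl without moving the read-out. The earlier large steps all swapped the whole ring, whereas this one keeps the ring and changes only what it carries. Compound 4 also stays away from the value shared by compound 2 and compound 3: the limit of > 100000 nM in this assay, at which 2 of the 4 values shown sit.

As far as these compounds go, whether an amine or a carboxylic acid at this place would leave the number equally unmoved remains open. So does whether the thiophene ring kept in compound 1 and compound 4 is what separates them from compound 2 and compound 3.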